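Methyl for Amino on the Thiadiazole: Limits Throughout

The source may hold more compounds than are shown below. What is called first, only, known or untested is meant among the compounds shown, and "the series" means these compounds.

Compound 1, `Cc1nnc(SCc2cc(=O)c3cc(Cl)ccc3o2)o1`: in a functional assay on HeLa cells (Homo sapiens) for cytotoxicity, read by MTT assay, with a stated time of 72 h (a lower number here means a stronger inhibitor, a higher number a weaker inhibitor), compound 1 gives > 25000 nM, a limit of the assay.
Compound 2, `Nc1nnc(SCc2cc(=O)c3cc(Cl)ccc3o2)s1`: in this assay compound 2 gives > 25000 nM, also a limit.
Compound 3, `Cc1ccc2oc(CSc3nnc(N)s3)cc(=O)c2c1`: in this assay compound 3 gives > 25000 nM, again a limit.

Among the measured compounds shown here, compound 2 therefore stands only at a limit, as all three values sit at the limit of > 25000 nM in this assay, at which 3 of the 3 values shown sit, and no compound can be placed relative to another. Compound 4, `Cc1nnc(SCc2cc(=O)c3cc(Cl)ccc3o2)s1`, differs from compound 2 by methyl in place of amino on an aromatic carbon. The two measured steps that bear on this change, a step that the two limits leave unreadable from compound 1 to compound 2 and a step that the two limits leave unreadable from compound 2 to compound 3, are both unreadable from their limits. Nothing therefore sizes the step for compound 4 in this assay, and the expected step is a step that the limit leaves unreadable from compound 2 to compound 4. Compound 4 is estimated at 50000 nM, between 20000 nM and 200000 nM, most likely reported only as a limit.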

Compound 4, half-maximal inhibitory concentration: > 25000 nM
Compound 4 was reported as a limit (the forecaster's own chance of this, stated with the estimate: 85%); the middle value is on the limit's open side.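

No step from compound 2 or compound 1 to compound 4 can be read, as all the values are limits: the limit of > 25000 nM in this assay, at which 4 of the 4 values shown sit.

Still open, from the compounds shown here alone, is whether 5-methyl-1,3,4-thiadiazol-2-yl and 5-amino-1,3,4-thiadiazol-2-yl differ at all in this assay.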